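A few compounds are considered here, and "the series" means these few. Any claim that something is new, unique, unknown or untested is made for them only; others in the source may bear on it.

Compound 3 `CC(C)n1ncc2c(C(=O)NCc3cn(-c4ccc(C(F)(F)F)cc4)nn3)cccc21` gives 38600 nM in a functional assay on PC-3 cells (Homo sapiens) for inhibition, read by MTT assay, with a stated time of 72 h (on this read-out lower numbers stand for stronger inhibition and higher numbers for weaker inhibition), the higher of the two numbers reported. Compound 2 `CC(C)n1ncc2c(C(=O)NCc3cn(-c4cccc(F)c4)nn3)cccc21` gives 36100 nM in this assay, and the step of a 1.1-fold higher number from compound 2 to compound 3 (0.03 log units; within the scatter) lies within the scatter. Compound 1 `CC(C)n1ncc2c(C(=O)NCc3cn(-c4ccc(I)cc4)nn3)cccc21` reaches only a limit in this assay, namely > 40000 nM. The steps of an at least 1.1-fold lower number from compound 1 to compound 2 (0.04 log units; that floor lies within the scatter) and an at least 1.0-fold lower number from compound 1 to compound 3 (0.01 log units; that floor lies within the scatter) are floors that sit within the scatter, so the three groups on the aromatic nitrogen are not separated by these numbers. Compound 4 `CC(C)n1ncc2c(C(=O)NCc3cn(Cc4ccccc4)nn3)cccc21` differs from compound 3 in one place: benzyl in place of 4-(trifluoromethyl)phenyl on an aromatic nitrogen. Within the data shown here, no measured step covers this kind of exchange, so the expected step of a 1.0-fold higher number from compound 3 to compound 4 (0.02 log units; within the scatter) is none beyond the scatter, with the limit of > 40000 nM in this assay, at which 1 of the 3 values shown sits, a real possibility. Compound 4 is therefore estimated at 40000 nM, expected between 20000 nM and 90000 nM.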

Compound 4, half-maximal inhibitory concentration: 4420 nM
Beside the measured number, compound 4's estimate is 9.0-fold (0.96 log units) above it; the measured number lies below the stated range.
By their numbers in this assay, from the lowest: compound 4; then compounds 2 and 3 (each within the scatter of the next). At a limit, above all of these: compound 1.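

The three phenyl groups on this aromatic nitrogen were not separated by the earlier numbers, whereas benzyl is clearly set apart from them: the result shows an 8.7-fold lower number from compound 3 to compound 4 (0.94 log units; beyond the scatter) and an 8.2-fold lower number from compound 2 to compound 4 (0.91 log units; beyond the scatter). The step of an at least 9.0-fold lower number from compound 1 to compound 4 (0.95 log units; beyond the scatter) points the same way, but it is only a floor, as compound 1 gives a limit: the limit of > 40000 nM in this assay, at which 1 of the 4 values shown sits. Open, on these data alone, is whether the gain depends on the carbon link of benzyl itself: an unsubstituted phenyl, a 2-phenylethyl chain or a benzyl carrying fluoro would bear on that.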